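The compounds below may be only part of what the source reports. "The series", "measured", "known", "first", "only" and "open" are said of these compounds alone.

Measured so far in an assay on membranes from CHO cells for displacement of a labelled ligand from adenosine receptor A1 (Homo sapiens), read by scintillation counting, with a stated time of 60 min, tested at 1 uM; a higher number here means more inhibition at the concentration tested (going by the name of the read-out), a lower number less inhibition:
compound 1 `CC1=C(C(=O)OCC(C)C)C(c2ccsc2)NC(=S)N1` gives 8%
compound 2 `CC1=C(C(=O)OC(C)(C)C)C(c2ccsc2)NC(=S)N1` gives 16%
compound 3 `CC1=C(C(=O)OCC(C)C)C(c2ccoc2)NC(=O)N1C` gives 4%

Compound 1 and compound 2 share one core and differ by tert-butyl in place of isobutyl on an oxygen next to a carbonyl group; this change gives a number 8 percentage points higher from compound 1 to compound 2 (within the scatter). Compound 3 stands on another core; the difference between the cores of compound 1 and compound 3 is not broken down here. Compound 3 sits lower than compound 2, while its value and that of compound 1 lie within the scatter of each other.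

Compound 4 `CC1=C(C(=O)OC(C)(C)C)C(c2ccoc2)NC(=O)N1C` is not yet measured. It differs from compound 3 by tert-butyl in place of isobutyl on an oxygen next to a carbonyl group, the same change at the same place as between compound 1 and compound 2. Because the earlier step was a number 8 percentage points higher from compound 1 to compound 2 (within the scatter), the expected step here is a number 6 percentage points higher from compound 3 to compound 4 (within the scatter), resting on that single pair only. Compound 4 is therefore expected near 10% in this assay, estimated between 0% and 24%.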

Compound 4, a percentage reported as inhibition, at one concentration (the size of the read-out at that concentration, not a potency): 21%
The estimate for compound 4 lay 11 percentage points below the measured number; the measured number falls inside the stated range.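

In this assay, tert-butyl in place of isobutyl on an oxygen next to a carbonyl group gives a number 17 percentage points higher from compound 3 to compound 4 (beyond the scatter). Set beside the earlier step, the two do not differ: the same change on two cores in this assay, a number 8 percentage points higher (within the scatter) from compound 1 to compound 2 and a number 17 percentage points higher (beyond the scatter) from compound 3 to compound 4, 9 percentage points apart, within the scatter of two such steps. The change thus carries from one core to the other in the same direction on these two pairs, but two pairs at a single concentration do not establish a step size or show that it would hold on any further core.

Open, on these data alone, is whether a shorter chain such as ethyl, or a carboxylic acid or amide in place of the ester, would follow the same course. Also open, as far as these compounds go, is which of the differences between the two cores, if any, bears on the size of the step.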